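Replacing a benzoyl with a 4-chlorophenyl on the sulfonamide

A few compounds are considered here, and "the series" means these few. Any claim that something is new, unique, unknown or untested is made for them only; others in the source may bear on it.

Measured compounds:
compound 1, `O=C(NS(=O)(=O)c1ccc(NC(=O)c2ccc(Cl)cc2Cl)cc1)c1ccccc1`, > 100000 nM
compound 2, `O=C(Nc1ccc(S(=O)(=O)NCc2ccccc2)cc1)c1ccc(Cl)cc1Cl`, > 100000 nM
compound 3, `Cc1cc(Cl)ccc1C(=O)Nc1ccc(S(=O)(=O)Nc2ccccc2)cc1`, 912 nM

In a functional assay on HEK293 cells for agonist activity at probable G-protein coupled receptor 27 (Homo sapiens), read by a luciferase reporter and beta-arrestin recruitment, with a stated time of 10 min (a lower number here means that less compound is needed, a higher number that more compound is needed for the effect), compound 1 reaches only the limit of the assay, > 100000 nM. Compound 2 likewise stops at the limit, > 100000 nM, so the step that the two limits leave unreadable from compound 1 to compound 2 cannot be sized. Compound 3, which carries a phenyl on the sulfonamide nitrogen, gives a measured value, 912 nM, in this assay. The unmeasured compound 4, `O=C(Nc1ccc(S(=O)(=O)Nc2ccc(Cl)cc2)cc1)c1ccc(Cl)cc1Cl`, differs from compound 1 in that (4-chlorophenyl in place of benzoyl on a sulfonamide nitrogen). Going by the values given here, no measured step covers this change directly; compound 1 sits at the limit of > 100000 nM in this assay, at which 2 of the 3 values shown sit, so the direction from it is bounded only on one side. The one aryl-bearing sulfonamide, compound 3, is the nearest guide, and an aryl on that nitrogen goes with a readable value there. Compound 4 is therefore expected to come in at about 700 nM, within 150 nM to 4000 nM, which would mean an expected step of an at least 140-fold lower number from compound 1 to compound 4 (2.15 log units; beyond the scatter).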

Compound 4, half-maximal effective concentration: > 100000 nM
Compound 4 was reported as a limit; the forecaster's own chance of this, stated with the estimate: 15%; at least 140-fold (2.15 log units) between middle value and limit.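

Compound 4 also stops at a limit: the limit of > 100000 nM in this assay, at which 3 of the 4 values shown sit.

Going by these compounds alone, no step from compound 1 or compound 2 to compound 4 can be read. The compounds shown leave open which difference goes with the readable value of compound 3, which differs from compound 4 in more than one place.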